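The compounds below may be only part of what the source reports. "The series", "measured", "known", "first", "only" and "open" are said of these compounds alone.

Of the compounds shown here, three sharing one core have been measured in a functional assay (muscle tissue) with Cavia porcellus as the target; on this read-out higher numbers stand for an effect only at larger amounts of compound and lower numbers for an effect already at smaller amounts: compound 1 (`COC(=O)C1=C(C)N=C(C)/C(=C(\O)OC)C1c1ccccc1I`) gives 46.8 nM, compound 2 (`COC(=O)C1=C(C)N=C(C)/C(=C(\O)OC)C1c1cccc(N)c1`) gives 2000 nM, and compound 3 (`COC(=O)C1=C(C)N=C(C)/C(=C(\O)OC)C1c1ccccc1C#N`) gives 15.9 nM. Compound 3 thus holds the lowest of the three numbers, and its gaps to both others lie beyond the scatter. The next compound, compound 4 (`COC(=O)C1=C(C)N=C(C)/C(=C(\O)OC)C1c1ccc(Br)cc1`), carries 4-bromophenyl in place of 2-cyanophenyl on a saturated ring carbon.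

All three measured steps exchange the group at this same place. Going between the 2-iodophenyl and 2-cyanophenyl groups moved the number only modestly, with a 2.9-fold lower number from compound 1 to compound 3 (0.47 log units; beyond the scatter). Moving to or from the 3-aminophenyl group moved it far more, with a 43-fold higher number from compound 1 to compound 2 (1.63 log units; beyond the scatter) and a 130-fold lower number from compound 2 to compound 3 (2.10 log units; beyond the scatter). For the measured compounds named here, no compound with a 4-bromophenyl group has been measured, so the comparison is indirect and rests on few compounds. Going by the values given here, still, compound 4 gives up the 2-cyanophenyl group for one outside that closely matched pair, and the only such exchange measured, in compound 2, is the large one. A large step towards a higher number is therefore expected. The estimated change is a 130-fold higher number from compound 3 to compound 4 (2.10 log units; beyond the scatter). Compound 4 is estimated at 2000 nM, with an expected range from 400 nM to 10000 nM.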

Compound 4, half-maximal effective concentration: 540 nM
Compound 4: middle estimate off by 3.7-fold (0.57 log units), on the high side; measured number inside the range.
By their numbers in this assay, from the lowest: compound 3; then compound 1; then compound 4; then compound 2.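

In this assay, the 4-bromophenyl group shows that a large rise at this saturated ring carbon is not confined to the 3-aminophenyl group, with a 34-fold higher number from compound 3 to compound 4 (1.53 log units; beyond the scatter) and a 12-fold higher number from compound 1 to compound 4 (1.06 log units; beyond the scatter). The two groups at the high end are still separated, with a 3.7-fold lower number from compound 2 to compound 4 (0.57 log units; beyond the scatter), a modest step but one beyond the scatter. Across the four compounds, the 2-iodophenyl and 2-cyanophenyl groups now hold the two lowest numbers and the 3-aminophenyl and 4-bromophenyl groups the two highest, and no compound shown goes against this split.

As far as these compounds go, the split remains open to two readings, since the high and low groups differ both in the substituent and in where it stands on the phenyl, and a 2-bromophenyl group set against the 4-bromophenyl group of compound 4, or a plain phenyl group, would be needed to tell these apart. Nothing given here offers a measured explanation for any of these steps.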